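The source may hold more compounds than are shown below. What is called first, only, known or untested is meant among the compounds shown, and "the series" means these compounds.

Compound 1 `O=C(/C=C/c1ccc(C(F)(F)F)cc1)c1c(O)c2ccccc2[nH]c1=O`: > 50000 nM
Compound 2 `CC(C)(C)c1cc(/C=C/C(=O)c2c(O)c3ccccc3[nH]c2=O)cc(C(C)(C)C)c1O`: 26200 nM
Compound 3 `CCn1c(=O)c(C(=O)/C=C/c2ccccc2C)c(O)c2ccccc21`: > 50000 nM

In an ADME assay on THP-1 cells (Homo sapiens) for cytotoxicity, read by MTT assay, with a stated time of 72 h (a higher number here means a weaker inhibitor, a lower number a stronger inhibitor), compound 1 gives > 50000 nM, which is a limit of the assay and not a number. Compound 2 gives 26200 nM in this assay. Compound 3 gives > 50000 nM, again a limit. Compound 1 therefore sits at the limit of > 50000 nM in this assay, at which 2 of the 3 values shown sit, and no ranking of the three compounds can be drawn from these values. Among the measured compounds shown here, no step between measured compounds is recorded here. Compound 4 `O=C(O)c1ccc(/C=C/C(=O)c2c(O)c3ccccc3[nH]c2=O)cc1` differs from compound 1 by carboxy in place of trifluoromethyl on an aromatic carbon. Given that both compounds bracketing this series sit at the limit, compound 4 is expected to give 80000 nM in this assay, within 30000 nM to 200000 nM, most likely again reported only as a limit. The expected step that the limit leaves unreadable from compound 1 to compound 4 is estimated to stay within the usual scatter.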

Compound 4, half-maximal inhibitory concentration: > 50000 nM
Compound 4: a limit, no number; the forecaster's own chance of this, stated with the estimate: 75%; the middle value lies beyond the limit too.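

Compound 4 gives > 50000 nM in this assay, a limit and not a number. Among the compounds shown here, compound 1 gives > 50000 nM, also a limit, so no step between compound 1 and compound 4 can be read. The compounds shown leave open whether carboxy in place of trifluoromethyl changes the value in this assay at all.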